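The compounds below may be only part of what the source reports. "The series", "measured", "known", "first", "only" and "open" are said of these compounds alone.

Compound 1 `Nc1cc(N)c2nc(-c3ccccc3)c(NCc3ccc(Cl)c(Cl)c3)nc2c1` gives 16200 nM in a functional assay on DU-145 cells (Homo sapiens) for inhibition, read by sulforhodamine B assay, with a stated time of 48 h; on this read-out higher numbers stand for weaker inhibition of growth and lower numbers for stronger inhibition of growth.
Compound 2 `COc1ccc(CNc2nc3cc(N)cc(N)c3nc2-c2ccccc2)cc1OC` gives 460 nM in this assay.
Compound 3 `CCOC(=O)[C@H](CCC(=O)O)NC(=O)c1ccc(Sc2nc3cc(N)cc(N)c3nc2-c2ccccc2)cc1` gives 69200 nM in this assay.

Of these three, compound 2 stands lowest in this assay, and its gaps to compound 1 and to compound 3 both lie beyond the usual scatter. Compound 4 `COc1cc(CNc2nc3cc(N)cc(N)c3nc2-c2ccccc2)cc(OC)c1OC` has not yet been measured. It differs from compound 2 in one place: methoxy in place of hydrogen on an aromatic carbon. Among the compounds with values here, the only measured step that touches this part of the shared core is the one in which the two chlorine-bearing positions of compound 1 were exchanged for methoxy groups, a 35-fold lower number from compound 1 to compound 2 (1.55 log units; beyond the scatter), a large step. Within the data shown here, that step, however, swapped one kind of group for another; no measured pair shows what a third methoxy added to the same ring does. The expectation is therefore cautious: a step of a 1.2-fold lower number from compound 2 to compound 4 (0.06 log units; within the scatter) is estimated, which is within the scatter. For compound 4 the estimated value in this assay is 400 nM, with a range from 120 nM to 1500 nM.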

Compound 4, concentration for 50% growth inhibition: 5250 nM
Estimate against measurement, compound 4: 13-fold (1.12 log units) below; measured number above the stated range.
By their numbers in this assay, from the lowest: compound 2; then compound 4; then compound 1; then compound 3.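

In this assay adding methoxy at this aromatic carbon, ortho to a methoxy group and meta to a large group, gives an 11-fold higher number from compound 2 to compound 4 (1.06 log units; beyond the scatter) and so moves the number in the direction of weaker inhibition of growth. The earlier step on this ring, a 35-fold lower number from compound 1 to compound 2 (1.55 log units; beyond the scatter), exchanged chlorine-bearing positions for methoxy groups, whereas this one shows that a further methoxy does not continue that fall: compound 2, with hydrogen at this carbon, keeps the lowest number of the four. Nothing shown here bears on the reason for this rise.

From the compounds shown here alone, whether a hydroxyl group or a fluorine atom at this same carbon would stay close to compound 2 remains open. So does whether the rise belongs to methoxy alone, which an ethoxy group there could help to test.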